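The source may report more compounds than this note shows. Statements on the series, on what has been measured and on what is new or still open speak of the compounds shown alone.

In a functional assay on EL4 cells (Mus musculus) for inhibition, tested at 100 uM (a lower number here means less inhibition, a higher number more inhibition at the concentration tested (going by the name of the read-out)), compound 1 `CCNc1nccc2c1ncn2C1O[C@H](CO)[C@@H](O)[C@H]1O` gives 8%. Compound 2 `OC[C@H]1OC(n2cnc3c(NCc4ccccc4)nccc32)[C@H](O)[C@@H]1O` gives in this assay 5%, and compound 3 `OCCNc1nccc2c1ncn2C1O[C@H](CO)[C@@H](O)[C@H]1O` gives 6%. Compound 3 stands as the second highest of the three numbers, with compound 2 nearest and compound 1 furthest, yet both gaps lie within the scatter: a number 1 percentage points higher from compound 2 to compound 3 (within the scatter), and a number 2 percentage points lower from compound 1 to compound 3 (within the scatter). The third step, a number 3 percentage points lower from compound 1 to compound 2 (within the scatter), is likewise within the scatter. Compound 4 `[N-]=[N+]=Nc1nccc2c1ncn2C1O[C@H](CO)[C@@H](O)[C@H]1O` differs from compound 3 in one place: azido in place of (2-hydroxyethyl)amino on an aromatic carbon. Among the measured compounds shown here, none of the measured steps touches this change directly; all three alter the chain carbon bound to the nitrogen on the aromatic ring while keeping that nitrogen, whereas in compound 4 the (2-hydroxyethyl)amino group leaves entirely and azido enters. What the measured steps do show is that three different groups at that place all give numbers within the scatter of one another, so there is no sign in these data that this place sets the read-out. The expected step is therefore a number 1 percentage points higher from compound 3 to compound 4 (within the scatter), none beyond the scatter. Compound 4 is estimated to give 7%, with a range from 0% to 20%.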

Compound 4, a percentage reported as inhibition, at one concentration (the size of the read-out at that concentration, not a potency): < 5%
Compound 4 gave a limit, no number; the forecaster's own chance of this, stated with the estimate: 5%; middle value at least 2 percentage points from the limit.
By their numbers in this assay, from the lowest: compounds 2, 3 and 1 (each within the scatter of the next).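

With azido, the nitrogen-linked chain leaves this aromatic carbon altogether, and in this assay compound 4 gives < 5%, which is a limit of the assay and not a number. Among the compounds shown here, replacing (2-hydroxyethyl)amino gives a number at least 1 percentage points lower from compound 3 to compound 4 (that floor lies within the scatter), replacing ethylamino gives a number at least 3 percentage points lower from compound 1 to compound 4 (that floor lies within the scatter), and replacing benzylamino gives a number no higher from compound 2 to compound 4 (the limit leaves the size open), so even this larger change, which removes the nitrogen link as well as the chain, shows no step that can be placed beyond the scatter. The step from benzylamino to azido cannot be read, and the other two steps are known only as floors, since the result for compound 4 is bounded by a limit: the limit of < 5% in this assay, at which 1 of the 4 values shown sits.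

As far as these compounds go, how far compound 4 truly lies from compounds 1, 2 and 3 therefore remains open, and so does whether this place has any hold on the read-out. The compounds shown also leave open whether a free amine, a carboxylic acid or a longer alkyl chain on this aromatic carbon would give a number clear of the scatter from those seen so far.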